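The compounds below may be only part of what the source reports. "The series", "measured", "known", "first", "only" and "open" are said of these compounds alone.

Two cores are compared in this study. Compound 1 `Cc1c(O)ccc2cc(-n3cc(/C=C/c4ccccc4)nn3)c(=O)oc12` bears a 2-phenylethenyl group, and in a functional assay on MCF7 cells (Homo sapiens) for antiproliferative activity (on this read-out lower numbers stand for stronger inhibition and higher numbers for weaker inhibition), compound 1 gives 33700 nM. Compound 3 `Cc1c(O)ccc2cc(-n3cc(-c4c[nH]c5ccccc45)nn3)c(=O)oc12` keeps the core of compound 1 and differs from it only by 1H-indol-3-yl in place of 2-phenylethenyl on an aromatic carbon. In this assay compound 3 gives 8170 nM, and the change made a 4.1-fold lower number from compound 1 to compound 3 (0.62 log units; beyond the scatter).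

Compound 2 `CO[C@@H]1[C@@H](O)[C@@H](O)[C@H](Oc2ccc3c(c2C)OC(=O)C(n2cc(/C=C/c4ccccc4)nn2)C3)OC1(C)C` carries the same 2-phenylethenyl group on a different core; how the two cores differ is not broken down here. In this assay compound 2 gives 14600 nM. Set against compound 1 this is a lower number beyond the scatter, while the values of compound 2 and compound 3 lie within the scatter of each other, so no order between those two can be read.

Compound 4 `CO[C@@H]1[C@@H](O)[C@@H](O)[C@H](Oc2ccc3c(c2C)OC(=O)C(n2cc(-c4c[nH]c5ccccc45)nn2)C3)OC1(C)C` has not yet been measured. It differs from compound 2 by 1H-indol-3-yl in place of 2-phenylethenyl on an aromatic carbon, which is the same change, at the same place, as that from compound 1 to compound 3. If the step repeats on the core of compound 2, the author expects a 3.7-fold lower number from compound 2 to compound 4 (0.56 log units; beyond the scatter), resting on the step of a 4.1-fold lower number from compound 1 to compound 3 (0.62 log units; beyond the scatter) seen with compound 1 and compound 3, and on the starting point set by compound 2, which gives 14600 nM. Since the change has been seen only once, the expectation is held loosely. For compound 4 in this assay the author estimates 4000 nM, with a range from 1500 nM to 12000 nM.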

Compound 4, half-maximal inhibitory concentration: 18300 nM
The estimate for compound 4 lay 4.6-fold (0.66 log units) below the measured number, outside the stated range (above it).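

On the core of compound 2, putting 1H-indol-3-yl in place of 2-phenylethenyl does not repeat what it did on the core of compound 1: in this assay the new step is a 1.3-fold higher number from compound 2 to compound 4 (0.10 log units; within the scatter), so this pair cannot be separated on this read-out. The same change thus gives different results on the two cores, and the gap between the two steps is larger than the scatter allows: the same change on two cores in this assay, a 4.1-fold lower number (0.62 log units; beyond the scatter) from compound 1 to compound 3 and a 1.3-fold higher number (0.10 log units; within the scatter) from compound 2 to compound 4, 5.2-fold (0.71 log units) apart, beyond the scatter of two such steps. Among these compounds, this shows that, in this series, the step seen on the core of compound 1 cannot simply be carried over to the core of compound 2, but it does not show which difference between the two cores is responsible or how the change would behave on any third core, and each core contributes only a single pair.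

The compounds shown leave open whether the step on the core of compound 1 is particular to 1H-indol-3-yl or would also appear with another group at this place on the five-membered aromatic ring with 3 nitrogen, such as an amine, a carboxylic acid or a longer chain. They also leave open whether any such group would give a step on the core of compound 2.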